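This account rests on a few compounds, and the source may have more. Where it says the series, first, only, none or still open, it means among the compounds named here.

Of the compounds shown here, three built on the same amide skeleton have been tested in an ADME assay on HepG2 cells (Homo sapiens) for cytotoxicity, with a stated time of 72 h; on this read-out higher numbers stand for an effect only at larger amounts of compound and lower numbers for an effect already at smaller amounts. Compound 1 `O=C(Nc1ccc(Cl)c(-c2nc3ccccc3s2)c1)c1cc([N+](=O)[O-])ccc1Cl`, compound 2 `COc1ccc(-c2nc3ccccc3s2)cc1NC(=O)c1cc([N+](=O)[O-])ccc1Cl` and compound 3 `COc1ccc(NC(=O)c2cc([N+](=O)[O-])ccc2Cl)cc1-c1nc2ccccc2s1` all carry a nitro-substituted, chloro-substituted benzamide joined to a benzothiazolyl-bearing aniline, differing only in the small group that sits on that aniline ring and in where the benzothiazolyl group is attached.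

In this assay compound 1 gives > 25000 nM, which is a limit of the assay rather than a number. Compound 2 likewise gives > 25000 nM, again a limit. Compound 3 gives > 25000 nM, also a limit. Because every one of the three values sits at the limit of > 25000 nM in this assay, at which 3 of the 3 values shown sit, the step that the two limits leave unreadable from compound 3 to compound 1 cannot be read: it is the change (chloro in place of methoxy on an aromatic carbon), but its size stays hidden between two limits.

Compound 4 `O=C(Nc1cc(-c2nc3ccccc3s2)ccc1Cl)c1cc([N+](=O)[O-])ccc1Cl` has not yet been measured. It is related to compound 2 by the same kind of change, (chloro in place of methoxy on an aromatic carbon); the place differs from the earlier one in that the new chloro sits ortho to a large group and para to a 1,3-benzothiazol-2-yl group, where in the earlier pair it sat ortho to the 1,3-benzothiazol-2-yl group and para to a large group. The difference between the cores of compound 2 and compound 3 is not broken down here.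

Given that compound 1, compound 2 and compound 3 all reached only the limit at the limit of > 25000 nM in this assay, at which 3 of the 3 values shown sit, the expected step from compound 2 is a step that the limit leaves unreadable from compound 2 to compound 4, which means no readable change. Compound 4 is therefore estimated at 30000 nM, most probably again reported only as a limit.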

Compound 4, half-maximal effective concentration: > 25000 nM
Compound 4: a limit, no number (the forecaster's own chance of this, stated with the estimate: 80%); the middle value lies beyond the limit too.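

In this assay compound 4 gives > 25000 nM, which is a limit of the assay and not a number. No size can therefore be read for the change from methoxy to chloro between compound 2 and compound 4: the limit of > 25000 nM in this assay, at which 4 of the 4 values shown sit.

The compounds shown leave open how far each one lies from that limit, and whether any of these structural differences alters the read-out at all.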